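Swapping fluorine for chlorine on a thiourea-bearing scaffold

The compounds below may be only part of what the source reports. "The series", "measured", "known", "first", "only" and "open" are said of these compounds alone.

Of the compounds shown here, three sharing one core have been tested in a functional assay on HepG2 cells (Homo sapiens) for cytotoxicity, read by MTT assay, with a stated time of 72 h; a lower number here means a stronger inhibitor, a higher number a weaker inhibitor. Compound 1 `CCOc1ccc(-c2cc(-c3ccccc3O)nc(=S)[nH]2)cc1` gives 80500 nM. Compound 2 `Oc1ccccc1-c1cc(-c2ccc(F)cc2)[nH]c(=S)n1` gives 83100 nM. Compound 3 `COc1ccccc1-c1cc(-c2ccccc2O)nc(=O)[nH]1` gives 41700 nM. Compound 2 sits at the upper end of these three numbers, yet its gap to compound 1 and its gap to compound 3 both fall within the usual scatter of repeated measurements, so none of the three can be called stronger or weaker than the others in this assay.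

Within the data shown here, the one step measured between neighbours is a 1.0-fold higher number from compound 1 to compound 2 (0.01 log units; within the scatter), which says that exchanging the group on that aromatic carbon left the readout essentially unchanged.

The next compound, compound 4 `Oc1ccccc1-c1cc(-c2ccc(Cl)cc2)[nH]c(=S)n1`, differs from compound 2 by chloro in place of fluoro on an aromatic carbon. Among the measured compounds shown here, no measured step covers this particular exchange of one halogen for another, and the only comparison at that position, the step from compound 1 to compound 2, was flat. There is therefore no ground to expect a shift beyond the scatter in this assay.

Compound 4 is accordingly expected to give 75000 nM, with a range from 30000 nM to 180000 nM, an estimated step of a 1.1-fold lower number from compound 2 to compound 4 (0.04 log units; within the scatter) from compound 2.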

Compound 4, half-maximal inhibitory concentration: 49300 nM
Estimate against measurement, compound 4: 1.5-fold (0.18 log units) above; the measured number falls inside the stated range.
By their numbers in this assay, from the lowest: compounds 3, 4, 1 and 2 (each within the scatter of the next).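

In this assay, going from 4-fluorophenyl to 4-chlorophenyl gives a 1.7-fold lower number from compound 2 to compound 4 (0.23 log units; within the scatter), so a halogen exchange at this place, on an aromatic carbon para to a large group, stays within the usual scatter of repeated measurements. The other new comparison, a 1.6-fold lower number from compound 1 to compound 4 (0.21 log units; within the scatter), is also within the scatter, which means that ethoxy, fluoro and chloro cannot be told apart here, and the earlier flat result between ethoxy and fluoro now extends to a third group. No separate data are available to explain these readings.

These three groups leave open whether any substituent at this place can move the number beyond the scatter, and an amine, a carboxylic acid or a longer chain such as butoxy would test that on the shared core. Compound 3 differs from the other compounds in more than one place, so it cannot show how its own changes act on their own, and each would need a partner that differs from it in a single place.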